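This account rests on a few compounds, and the source may have more. Where it says the series, first, only, none or still open, it means among the compounds named here.

In a functional assay on NCI-H23 cells (Homo sapiens) for cytotoxicity, read by sulforhodamine B assay, with a stated time of 72 h (on this read-out higher numbers stand for weaker inhibition of growth and lower numbers for stronger inhibition of growth), compound 3 `O=C(Nc1ccccc1C(F)(F)F)C1CCc2ccccc2N1C(=O)c1ccccc1` gives 6340 nM, the lowest of the two numbers shown. Compound 1 `O=C(Nc1ccccc1C(F)(F)F)C1CCc2ccccc2N1` gives 56800 nM; the step of a 9.0-fold lower number from compound 1 to compound 3 (0.95 log units; beyond the scatter) is the one that puts a benzoyl group on the ring nitrogen. Compound 2 `CCC(=O)N1c2ccccc2CCC1C(=O)Nc1ccccc1C(F)(F)F` reaches only the limit > 80000 nM in this assay. The steps of an at least 12-fold lower number from compound 2 to compound 3 (1.10 log units; beyond the scatter) and an at least 1.4-fold higher number from compound 1 to compound 2 (0.14 log units; that floor lies within the scatter) show that the benzoyl, rather than a propanoyl, brings the number down. Compound 4 `O=C(Nc1ccccc1C(F)(F)F)C1CCc2ccccc2N1C(=O)c1ccccc1Cl` differs from compound 3 by chloro in place of hydrogen on an aromatic carbon. For the measured compounds named here, none of the measured steps changes the benzoyl ring itself, so no step bears directly on this change; the benzoyl steps only set the scale. A step of about a 1.3-fold lower number from compound 3 to compound 4 (0.10 log units; within the scatter) is expected, within the scatter. Compound 4 is therefore estimated at 5000 nM, between 1500 nM and 20000 nM.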

Compound 4, concentration for 50% growth inhibition: 2150 nM
Estimate against measurement, compound 4: 2.3-fold (0.37 log units) above; measured number inside the range.
By their numbers in this assay, from the lowest: compound 4; then compound 3; then compound 1. At a limit, above all of these: compound 2.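

Compound 4 shows that the benzoyl ring itself can shift this read-out: chloro on an aromatic carbon, ortho to a large group, gives a 2.9-fold lower number from compound 3 to compound 4 (0.47 log units; beyond the scatter). The full (2-chlorophenyl)carbonyl group on the ring nitrogen gives a 26-fold lower number from compound 1 to compound 4 (1.42 log units; beyond the scatter). Against the propanoyl, the step of an at least 37-fold lower number from compound 2 to compound 4 (1.57 log units; beyond the scatter) is only a floor: the limit of > 80000 nM in this assay, at which 1 of the 4 values shown sits.

Only one substituent on this ring is shown, so whether a methyl or methoxy group on the same carbon would do the same stays open. As far as these compounds go, whether chloro elsewhere on the ring would match it also stays open.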